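The source may hold more compounds than are shown below. What is called first, only, known or untested is meant among the compounds shown, and "the series" means these compounds.

Compounds measured in an ADME assay on Vero cells (Chlorocebus sabaeus) for cytotoxicity, read by fluorescence, with a stated time of 4 days; a higher number here means a weaker inhibitor, a lower number a stronger inhibitor:
compound 1, `COC1=C(CC(C)(C)CNC(=O)c2ccc3ccccc3c2OC)C(=O)c2ccccc2C1=O` — 60600 nM
compound 2, `COc1c(C(=O)NCC(C)(C)CC2=C(O)C(=O)c3ccccc3C2=O)ccc2ccccc12` — 47300 nM
compound 3, `COc1ccc(O)c(C(=O)NCC(C)(C)CC2=C(O)C(=O)c3ccccc3C2=O)c1` — 31100 nM

Compound 1 and compound 2 share a core and differ by one change, (methyl in place of hydrogen on an oxygen on an unsaturated carbon), which gave a 1.3-fold higher number from compound 2 to compound 1 (0.11 log units; within the scatter). The difference between the core of compound 2 and the core of compound 3 is not broken down here; their two values lie within the scatter of each other, as do those of compound 3 and compound 1.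

Compound 4, `COc1ccc(OC)c(C(=O)NCC(C)(C)CC2=C(O)C(=O)c3ccccc3C2=O)c1`, has not been measured in this assay. It differs from compound 3 by methyl in place of hydrogen on an oxygen on an aromatic ring. This is the same kind of change as that from compound 2 to compound 1, but not the same: there the oxygen sits on an unsaturated carbon whose other neighbour is a double-bonded ring carbon, here on an aromatic ring whose other neighbour is an aromatic carbon. The step from compound 3 to compound 4 is expected to be a 1.3-fold higher number from compound 3 to compound 4 (0.11 log units; within the scatter), resting on compound 2 to compound 1 giving a 1.3-fold higher number from compound 2 to compound 1 (0.11 log units; within the scatter). Compound 4 is thus estimated at 40000 nM, within 20000 nM to 80000 nM.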

Compound 4, half-maximal inhibitory concentration: 89100 nM
Estimate against measurement, compound 4: 2.2-fold (0.35 log units) below, outside the stated range (above it).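

In this assay, methyl in place of hydrogen on an oxygen on an aromatic ring gave a 2.9-fold higher number from compound 3 to compound 4 (0.46 log units; beyond the scatter), a modest step. Set beside the earlier step on the other core, this result gives no firm sign that the change behaves differently from one core to the other, even though only the newer step lies beyond the scatter: the same change on two cores in this assay, a 1.3-fold higher number (0.11 log units; within the scatter) from compound 2 to compound 1 and a 2.9-fold higher number (0.46 log units; beyond the scatter) from compound 3 to compound 4, 2.2-fold (0.35 log units) apart, within the scatter of two such steps

For the compounds shown here, with only two pairs, the data show neither that the step carries over unchanged between cores nor that its size depends on the core, and the oxygen also differs between the pairs, sitting on an unsaturated carbon in one and on an aromatic ring in the other. The compounds shown leave open how an ethyl group or a longer chain on that oxygen, or an amine in place of the hydroxy group, would read in this assay. They also leave open whether the change from 2-hydroxy-5-methoxyphenyl to 2,5-dimethoxyphenyl would give a similar step on a third core.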